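A few compounds are considered here, and "the series" means these few. Any claim that something is new, unique, unknown or untested is made for them only; others in the source may bear on it.

Compound 1 `CCOC(=O)CCCCCOc1cccc(CN(C(=O)c2ccc(-c3ccoc3)cc2)C(C)C)c1` gives > 26000 nM in an ADME assay on Raji cells (Homo sapiens) for cytotoxicity, read by CellTiter-Glo and resazurin assay, with a stated time of 72 h; on this read-out lower numbers stand for an effect already at smaller amounts and higher numbers for an effect only at larger amounts of compound. Compound 2 `CCOC(=O)CCCCCOc1cccc(CN(C(=O)c2ccc(-c3ccco3)cc2)C(C)C)c1` gives > 26000 nM in this assay. Compound 3 `CCOC(=O)CCCCCOc1cccc(CN(C(=O)c2ccc(-c3ccc4cc[nH]c4c3)cc2)C(C)C)c1` gives > 26000 nM in this assay.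

Each of these values is a limit of the assay, not a number. Because (the limit of > 26000 nM in this assay, at which 3 of the 3 values shown sit), compound 3 stands where every measured compound stands, at the top of what the assay can report. The steps a step that the two limits leave unreadable from compound 1 to compound 2, a step that the two limits leave unreadable from compound 1 to compound 3 and a step that the two limits leave unreadable from compound 2 to compound 3 therefore give no readable size. Compound 4 `CCOC(=O)CCCCCOc1cccc(CN(C(=O)c2ccc(-c3cc(OC)cc(OC)c3)cc2)C(C)C)c1` differs from compound 3 in one place: 3,5-dimethoxyphenyl in place of 1H-indol-6-yl on an aromatic carbon. With no readable step to lean on, compound 4 is expected to stay at the limit as well, so the step that the limit leaves unreadable from compound 3 to compound 4 is estimated to be none beyond the scatter. The estimate for compound 4 is 30000 nM, ranging from 15000 nM to 60000 nM.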

Compound 4, half-maximal effective concentration: > 26000 nM
Compound 4 ended at the assay's limit; the forecaster's own chance of this, stated with the estimate: 85%; the middle value is on the limit's open side.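

Compound 4 gives > 26000 nM in this assay, which is a limit and not a number, and its steps from compound 1, compound 2 and compound 3 cannot be read. The compounds shown leave open how these four actually differ in this read-out.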